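This account rests on a few compounds, and the source may have more. Where it says the series, first, only, none or still open, it means among the compounds named here.

Of the compounds shown here, three that share one core have been tested in an assay on CHO cells for inhibition of Glucagon receptor (Homo sapiens), tested at 20 uM; on this read-out lower numbers stand for less inhibition and higher numbers for more inhibition at the one concentration tested (going by the name of the read-out). Compound 1 `CCC/C=C/c1c(C(C)C)nc(C(C)C)c(CO)c1-c1ccc(Cl)c(Cl)c1` gives 39% in this assay. Compound 2 `CCCCCc1c(C(C)C)nc(C(C)C)c(CO)c1-c1cccc(Cl)c1` gives 49%, and compound 3 `CCCCCc1c(C(C)C)nc(C(C)C)c(CO)c1-c1cccc(C(F)(F)F)c1` gives 25%. For the measured compounds named here, of these three numbers compound 2 stands highest, but its gap to compound 1 lies within the usual scatter; only its gap to compound 3 lies beyond it, and that gap is the one measured step here, a number 24 percentage points lower from compound 2 to compound 3 (beyond the scatter), a trifluoromethyl in place of chloro on an aromatic carbon. The unmeasured compound 4 `CCCCCc1c(C(C)C)nc(C(C)C)c(CO)c1-c1ccc(OC)cc1` differs from compound 2 in one place: 4-methoxyphenyl in place of 3-chlorophenyl on an aromatic carbon. The change sits on an aromatic carbon of the core, ortho to a hydroxymethyl group and ortho to a pentyl group, opposite the ring nitrogen. Going by the values given here, no measured step swaps one whole aryl group for another, so the only guide is the modest fall seen in a number 24 percentage points lower from compound 2 to compound 3 (beyond the scatter) when the group on that ring was altered. A step of similar or smaller size downward, or none beyond the scatter, is therefore expected, which is the estimated step of a number 14 percentage points lower from compound 2 to compound 4 (beyond the scatter). Compound 4 is expected to give 35%, in the range from 15% to 55%.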

Compound 4, a percentage reported as inhibition, at one concentration (the size of the read-out at that concentration, not a potency): 37%
The estimate for compound 4 lay 2 percentage points below the measured number; measured number inside the range.
By their numbers in this assay, from the lowest: compound 3; then compounds 4, 1 and 2 (each within the scatter of the next, the first and the last beyond it).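

For the compounds shown here, until now, the only change at this position was to the substituent on the meta-chlorinated aryl ring's place, so this is the first exchange of one whole aryl group for another: with 4-methoxyphenyl in place of 3-chlorophenyl, a number 12 percentage points lower from compound 2 to compound 4 (beyond the scatter) in this assay. Two different replacements of a chloro-bearing aryl arrangement, trifluoromethyl in a number 24 percentage points lower from compound 2 to compound 3 (beyond the scatter) and now 4-methoxyphenyl, both give lower numbers, though this rests on only those two steps. With a group carrying a hydrogen-bond acceptor at this position, compound 4 gives 37%.

This step alters both the substituent and where it sits on the phenyl ring, and the two effects cannot be separated here, while a phenyl ring carrying an amine or a carboxylic acid remains untested in what is shown. Nothing available explains why the number fell.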